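A few compounds are considered here, and "the series" means these few. Any claim that something is new, unique, unknown or untested is made for them only; others in the source may bear on it.

Measured so far in an assay on isolated protein for inhibition of ATP-dependent RNA helicase DDX3X (Homo sapiens), read by FRET, with stated times of 30 s and 40 min; a lower number here means a stronger inhibitor, a higher number a weaker inhibitor:
compound 1 `CCCCc1cn(-c2ccc(NC(=O)Nc3cc(OC4CCCC4)ccc3C)cc2)nn1`: 140 nM
compound 2 `Cc1ccccc1NC(=O)Nc1ccc(-n2cc(CCCN3CCN(C)CC3)nn2)cc1`: 40100 nM
compound 3 `CCOCc1cn(-c2ccc(NC(=O)Nc3cc(C(C)C)ccc3C)cc2)nn1`: 1510 nM

Compound 1 has the lowest number of the three. Compound 3 sits above it by more than the scatter, and compound 2 lies further above still; neither of those two pairs is a single-point change, so only the raw values are compared here.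

Compound 4 `CCCCc1cn(-c2ccc(NC(=O)Nc3cc(O[C@H]4O[C@@H](CO)[C@H](O)[C@@H]4O)ccc3C)cc2)nn1` is compound 1 altered at one place: 3,4-dihydroxy-5-(hydroxymethyl)oxolan-2-yl in place of cyclopentyl on an oxygen on an aromatic ring. Among the measured compounds shown here, no measured pair shows a change of this kind, and the entering group carries far more heavy atoms, donors and acceptors than anything varied among the three measured compounds. The step is expected to be toward a weaker inhibitor and beyond the scatter, estimated as a 21-fold higher number from compound 1 to compound 4 (1.33 log units; beyond the scatter). Compound 4 is accordingly expected near 3000 nM, within a range from 600 nM to 15000 nM.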

Compound 4, half-maximal inhibitory concentration: "not active" (no number reported)
Compound 4: no number reported; there is nothing to compare the estimate with.
By their numbers in this assay, from the lowest: compound 1; then compound 3; then compound 2.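

In this assay, among the compounds shown here, compound 4 is reported as not active, without a number, so no step from compound 1 at 140 nM can be read. The compounds shown leave open how much weaker compound 4 is than compound 1. No measurement at hand bears on this result.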